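The compounds below may be only part of what the source reports. "The series", "measured", "known", "first", "only" and "open" are said of these compounds alone.

Working notes on the series. In a functional assay on SW-620 cells (Homo sapiens) for cytotoxicity, read by sulforhodamine B assay, with a stated time of 48 h (on this read-out lower numbers stand for stronger inhibition and higher numbers for weaker inhibition), compound 1 `COc1ccc(C2=NO[C@]3(C2)C(=O)O[C@@H]2[C@H]3CC[C@H](C)[C@]3(O)C=CC(=O)[C@@]23C)cc1` gives 41000 nM, compound 2 `C[C@H]1CC[C@@H]2[C@@H](OC(=O)[C@]23CC(c2ccccc2Br)=NO3)[C@]2(C)C(=O)C=C[C@@]12O` gives 44000 nM, and compound 3 `C[C@H]1CC[C@@H]2[C@@H](OC(=O)[C@]23CC(c2ccc([N+](=O)[O-])cc2)=NO3)[C@]2(C)C(=O)C=C[C@@]12O` gives 9000 nM, the lowest of the three; the steps of a 4.6-fold lower number from compound 1 to compound 3 (0.66 log units; beyond the scatter) and a 4.9-fold lower number from compound 2 to compound 3 (0.69 log units; beyond the scatter) lie beyond the scatter, while a 1.1-fold higher number from compound 1 to compound 2 (0.03 log units; within the scatter) does not. Compound 4 `Cc1ccc(C2=NO[C@]3(C2)C(=O)O[C@@H]2[C@H]3CC[C@H](C)[C@]3(O)C=CC(=O)[C@@]23C)cc1` is unmeasured and differs from compound 3 by methyl in place of nitro on an aromatic carbon. Among the compounds with values here, no measured step exchanges nitro for methyl; the nearest guide is nitro in place of methoxy, a 4.6-fold lower number from compound 1 to compound 3 (0.66 log units; beyond the scatter), which suggests the number rises again once the nitro group is removed. A step upward of roughly that size is expected, a 3.9-fold higher number from compound 3 to compound 4 (0.59 log units; beyond the scatter). Compound 4 is accordingly estimated at 35000 nM, within a range of 12000 nM to 90000 nM.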

Compound 4, half-maximal inhibitory concentration: 2500 nM
Beside the measured number, compound 4's estimate is 14-fold (1.15 log units) above it; the measured number lies below the stated range.
By their numbers in this assay, from the lowest: compound 4; then compound 3; then compounds 1 and 2 (each within the scatter of the next).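

In this assay, within the data shown here, on the aromatic carbon para to a large group, methyl gives the lowest number so far: a 3.6-fold lower number from compound 3 to compound 4 (0.56 log units; beyond the scatter), a 16-fold lower number from compound 1 to compound 4 (1.21 log units; beyond the scatter), and, with the whole aryl group exchanged, an 18-fold lower number from compound 2 to compound 4 (1.25 log units; beyond the scatter). The nitro group is therefore not needed for the lower number at this position, and the small methyl group goes further than nitro. No measurement shown here accounts for this order of groups. Going by these compounds, how an ethyl group, a longer chain, an amine or a carboxylic acid would behave at this position remains open.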